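The source may hold more compounds than are shown below. What is called first, only, known or untested is meant among the compounds shown, and "the series" means these compounds.

Within the data shown here, compound 3 (`O=c1cc(N2CCN(CC3CCC(O)CC3)CC2)sc2c([N+](=O)[O-])cc(C(F)(F)F)cc12`) carries a free hydroxy group and, at 51.2% in an ADME assay on cells (Hepatocyte, Mus musculus) for metabolic stability, with a stated time of 30 min (a higher number here means that more of the compound is left, a lower number that less of the compound is left), stands highest of the three numbers so far. Compound 1 (`Cc1ccc(C(=O)OC2CCC(CN3CCN(c4cc(=O)c5cc(C(F)(F)F)cc([N+](=O)[O-])c5s4)CC3)CC2)cc1`) gives 18% there and compound 2 (`O=C(OC1CCC(CN2CCN(c3cc(=O)c4cc(C(F)(F)F)cc([N+](=O)[O-])c4s3)CC2)CC1)C1CCCCC1`) gives 1.2% there. Compound 4 (`COc1ccc(C(=O)OC2CCC(CN3CCN(c4cc(=O)c5cc(C(F)(F)F)cc([N+](=O)[O-])c5s4)CC3)CC2)cc1`) has (4-methoxyphenyl)carbonyl in place of hydrogen on the oxygen ((4-methoxyphenyl)carbonyl in place of hydrogen on an oxygen on a saturated carbon). The measured steps bearing on this run the opposite way and are both large: a number 33.2 percentage points higher from compound 1 to compound 3 (beyond the scatter) when (4-methylphenyl)carbonyl is removed, and a number 50 percentage points higher from compound 2 to compound 3 (beyond the scatter) when cyclohexylcarbonyl is removed. The aromatic group of compound 1 is the closer model, so a large drop is expected (a number 36.2 percentage points lower from compound 3 to compound 4 (beyond the scatter)). Compound 4 is estimated at 15% in this assay, with an expected range from 4% to 32% here.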

Compound 4, percent of the compound remaining: 31%
The estimate for compound 4 lay 16 percentage points below the measured number; the range from low to high includes it.
By their numbers in this assay, from the lowest: compound 2; then compound 1; then compound 4; then compound 3.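

Putting a 4-methoxyphenyl ester on this oxygen still lowers the number compared with the free hydroxy group (a number 20.2 percentage points lower from compound 3 to compound 4 (beyond the scatter)) in this assay. The group at the far end of the ring counts as well, since methoxy in place of methyl gives a clear rise (a number 13 percentage points higher from compound 1 to compound 4 (beyond the scatter)). The aromatic ring again does better than a saturated one (a number 29.8 percentage points higher from compound 2 to compound 4 (beyond the scatter)), so the ester's outer group shapes the result.

Nothing measured here gives a reason for these differences. From the compounds shown here alone, whether an amide in place of the ester link, or a 4-fluorophenyl group on the carbonyl, would stay nearer to compound 3 remains open.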